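Swapping nitro for trifluoromethyl on a hydroxy thiazine core

The source may report more compounds than this note shows. Statements on the series, on what has been measured and on what is new or still open speak of the compounds shown alone.

Measured compounds:
- compound 1 `CCCCOC1(c2ccc(Br)cc2)SC=C(C)n2c1noc2=O`: 82000 nM
- compound 2 `CC1=CSC(O)(c2cccc([N+](=O)[O-])c2)c2noc(=O)n21`: 159000 nM

In a functional assay on A2780 cells (Homo sapiens) for antiproliferative activity, read by MTT assay, with a stated time of 3 days (on this read-out higher numbers stand for weaker inhibition and lower numbers for stronger inhibition), compound 1 gives 82000 nM and compound 2 gives 159000 nM; the two numbers lie within the usual scatter of each other, so neither compound can be called the weaker one. Compound 3 `CC1=CSC(O)(c2cccc(C(F)(F)F)c2)c2noc(=O)n21` is not yet measured. It differs from compound 2 by trifluoromethyl in place of nitro on an aromatic carbon. Among the compounds with values here, no comparable step has been measured here, so the expected step from compound 2 to compound 3 in this assay is small, a 1.3-fold lower number from compound 2 to compound 3 (0.12 log units; within the scatter), with no clear direction beyond the scatter. Compound 3 is therefore estimated at 120000 nM, within a range of 40000 nM to 400000 nM.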

Compound 3, half-maximal inhibitory concentration: 60000 nM
The estimate for compound 3 lay 2.0-fold (0.30 log units) above the measured number; low and high end bracket the measured number.
By their numbers in this assay, from the lowest: compounds 3, 1 and 2 (each within the scatter of the next, the first and the last beyond it).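

Trifluoromethyl in place of nitro on the aromatic carbon gives a 2.7-fold lower number from compound 2 to compound 3 (0.42 log units; beyond the scatter) in this assay and so shows that this position responds to the group it carries. Within the data shown here, the step is modest, yet it is the first here that can be read beyond the scatter. Nothing measured here accounts for it.

Going by these compounds, whether an amine or a carboxylic acid at this same place would lower the number further remains open. So does whether the same swap would give a similar step on the core of compound 1.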